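Benzyl Thioether Replacing Chlorophenacyl on a Trimethoxyphenyl Triazole

This account rests on a few compounds, and the source may have more. Where it says the series, first, only, none or still open, it means among the compounds named here.

Within the data shown here, compound 3 `COc1cc(-c2nnc(SCC(=O)c3ccc(Cl)cc3)n2N2C(=O)c3ccccc3C2=O)cc(OC)c1OC` is the only member of this set with a numerical result: in a functional assay on MKN-45 cells (Homo sapiens) for cytotoxicity, read by MTT assay, with a stated time of 48 h (a lower number here means a stronger inhibitor, a higher number a weaker inhibitor), compound 3 gives 26600 nM. Compound 1 `CCc1nnc(SCc2ccccc2)n1N1C(=O)c2ccccc2C1=O` reaches only a limit of the assay, > 200000 nM. Compound 2 `CCCc1nnc(SCc2ccccc2)n1N1C(=O)c2ccccc2C1=O` likewise gives only a limit, > 200000 nM. The step that the two limits leave unreadable from compound 1 to compound 2 therefore cannot be read. Compound 4 `COc1cc(-c2nnc(SCc3ccccc3)n2N2C(=O)c3ccccc3C2=O)cc(OC)c1OC` differs from compound 3 by phenyl in place of (4-chlorophenyl)carbonyl on a saturated chain carbon bound to a sulfur. Among the measured compounds shown here, no measured step alters this position, and the single measured step concerns another site and is itself unreadable. Both compounds carrying the benzylsulfanyl group sit at the limit of > 200000 nM in this assay, at which 2 of the 3 values shown sit, though each also lacks the trimethoxyphenyl of compound 3. Compound 4 is therefore expected to be weaker, by an estimated step of a 3.8-fold higher number from compound 3 to compound 4 (0.58 log units; beyond the scatter). The estimate for compound 4 is 100000 nM, with a range from 30000 nM to 300000 nM.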

Compound 4, half-maximal inhibitory concentration: > 200000 nM
Compound 4: no number, only a limit (the forecaster's own chance of this, stated with the estimate: 45%); middle value at least 2.0-fold (0.30 log units) from the limit.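

In this assay, among these compounds, phenyl in place of (4-chlorophenyl)carbonyl on a saturated chain carbon bound to a sulfur gives the first readable step at this position: an at least 7.5-fold higher number from compound 3 to compound 4 (0.87 log units; beyond the scatter). The 3,4,5-trimethoxyphenyl group of compound 4 therefore does not by itself yield a number once benzylsulfanyl is present. Compound 4 is one more compound at a limit, not a number: the limit of > 200000 nM in this assay, at which 3 of the 4 values shown sit.

The steps linking compound 4 to compound 1 and compound 2 cannot be read. From the compounds shown here alone, the change removes both the carbonyl and the chlorine, so it remains open which one matters; a 4-chlorobenzyl or a plain benzoylmethyl group would separate them.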